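The compounds below may be only part of what the source reports. "The series", "measured", "known", "first", "only" and "open" are said of these compounds alone.

In an assay on isolated protein for displacement of a labelled ligand from growth hormone secretagogue receptor type 1 (Homo sapiens), with a stated time of 1 h (a lower number here means a stronger inhibitor, a higher number a weaker inhibitor), three compounds of this series have been measured. Compound 1, `CC(C)(N)C(=O)N[C@H](COCc1ccccc1)c1nnn(Cc2ccc(NS(C)(=O)=O)cc2)n1`, gives > 5000 nM, which is a limit of the assay and not a number. Compound 2, `CC(C)(N)C(=O)N[C@H](COCc1ccccc1)c1nnn(C/C=C/c2ccccc2)n1`, likewise gives > 5000 nM, again a limit. For the measured compounds named here, the one recorded step, a step that the two limits leave unreadable from compound 1 to compound 2, is therefore unreadable. Going by the values given here, compound 3, `CC(C)(N)C(=O)N[C@H](COCc1ccccc1)c1nnn(CCCc2ccccc2NS(C)(=O)=O)n1`, gives 2390 nM, the only number among the three values shown, the other two sitting at the limit of > 5000 nM in this assay, at which 2 of the 3 values shown sit. Compound 4, `CC(C)(N)C(=O)N[C@H](COCc1ccccc1)c1nnn(CCCCC#N)n1`, has not yet been measured. It differs from compound 3 by cyanomethyl in place of 2-(methanesulfonamido)phenyl on a saturated chain carbon, three bonds along the chain from an aromatic nitrogen. Among the compounds with values here, no measured step bears directly on this change: the sole step on record cannot be read, and no measured pair shows what happens when the 2-(methanesulfonamido)phenyl group is removed from this chain. What can be said is that compound 3 alone gave a number, and the change to compound 4 removes most of the heavy atoms of that side chain. The step of a 2.9-fold higher number from compound 3 to compound 4 (0.47 log units; beyond the scatter) is therefore expected to be a loss, with little confidence in its size. Compound 4 is expected to give 7000 nM, within a range from 2000 nM to 25000 nM, and it may well return only a limit.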

Compound 4, inhibition constant: > 5000 nM
Compound 4 ended at the assay's limit; the forecaster's own chance of this, stated with the estimate: 65%; the middle value is on the limit's open side.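

In this assay compound 4 gives > 5000 nM, which is a limit of the assay and not a number. Even so, cyanomethyl in place of 2-(methanesulfonamido)phenyl on a saturated chain carbon, three bonds along the chain from an aromatic nitrogen, gives an at least 2.0-fold higher number from compound 3 to compound 4 (0.32 log units; beyond the scatter), the first step in this series whose direction can be read, and it shows that the measurable value of compound 3 does not survive this change. The steps joining compound 4 to compound 1 and to compound 2 cannot be read, because each has a limit at both ends: the limit of > 5000 nM in this assay, at which 3 of the 4 values shown sit.

For the compounds shown here, compound 3 remains the only compound with a number, and its step to compound 4 changes the aromatic ring and the methanesulfonamido group together, leaving open which of them matters. Going by these compounds, whether an unsubstituted phenyl, a carboxylic acid, an amine or a longer chain at this place would keep or improve on compound 3 also stays open.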